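From Dichlorophenoxy to Fluorophenoxy on a Shared Core

The compounds below may be only part of what the source reports. "The series", "measured", "known", "first", "only" and "open" are said of these compounds alone.

Three compounds built on a shared core have been examined in a functional assay on OVCAR-8 cells (Homo sapiens) for inhibition, read by sulforhodamine B assay, with a stated time of 48 h; a lower number here means that less compound is tolerated, a higher number that more compound is tolerated. Compound 1 `Nc1cc(N)c2nc(-c3ccccc3)c(Oc3ccc(Cl)c(Cl)c3)nc2c1` returns only a limit of the assay rather than a number, < 100000 nM. Compound 2 `Nc1cc(N)c2nc(-c3ccccc3)c(NCc3ccc(Cl)c(Cl)c3)nc2c1` likewise stops at a limit, < 100000 nM. Compound 3 `CCOC(=O)[C@H](CCC(=O)O)NC(=O)c1ccc(Sc2nc3cc(N)cc(N)c3nc2-c2ccccc2)cc1` also gives a limit, < 100000 nM. For the measured compounds named here, all three therefore rest at the same boundary, (the limit of < 100000 nM in this assay, at which 3 of the 3 values shown sit), so compound 1 cannot be ranked against its companions, and no step between measured compounds can be read from these data.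

Compound 4 `Nc1cc(N)c2nc(-c3ccccc3)c(Oc3ccc(F)cc3)nc2c1` differs from compound 1 in a single place: 4-fluorophenyl in place of 3,4-dichlorophenyl on an oxygen on an aromatic ring. With every measured value a limit, nothing here shows how such a change moves the read-out, and the expected step in this assay is none beyond the scatter, so the estimated step that the limit leaves unreadable from compound 1 to compound 4 is set at no change. Compound 4 is accordingly expected to land near 50000 nM in this assay, within a range from 10000 nM to 100000 nM, with a real chance that only a limit is reported once more.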

Compound 4, concentration lethal to 50% of the cells: 100000 nM
Compound 4: the middle estimate sits 2.0-fold (0.30 log units) below what was measured; measured number inside the range.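

In this assay, for the compounds shown here, compound 4 gives a plain number, 100000 nM, the only value in this set that is not a limit. Placing 4-fluorophenyl in place of 3,4-dichlorophenyl on an oxygen on an aromatic ring gives a number no lower from compound 1 to compound 4 (the limit leaves the size open), so the change does not lower the read-out, although its size cannot be read. The number is the same figure as the boundary the other compounds stop at, so this position still cannot be graded: the limit of < 100000 nM in this assay, at which 3 of the 4 values shown sit.

The compounds shown leave open whether the read-out follows the loss of the chlorines or the arrival of the fluorine. They also leave open how a plain phenyl, a methoxy group or a nitrile on that ring would read, and whether any such group would give a number well clear of the boundary.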